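Amide for ester on two different cores

The source may hold more compounds than are shown below. What is called first, only, known or untested is meant among the compounds shown, and "the series" means these compounds.

Of the compounds shown here, three have been measured in a functional assay on L1210 cells (Mus musculus) for antiproliferative activity; a lower number here means a less potent compound, a higher number a more potent compound, by a factor of ten per unit of this negative logarithm. Compound 1 `CN(C)/N=N/c1n[nH]cc1C(N)=O` gives 3.49, compound 2 `CCOC(=O)c1c[nH]nc1/N=N/N(C)C` gives 3.35, and compound 3 `CCOC(=O)c1ccc(/N=N/N(C)CC)cc1` gives 3.01, the lowest of the three, with both other numbers beyond the scatter from it. Compound 2 and compound 1 share a core and differ by one change, (amino in place of ethoxy on a carbonyl carbon), and the step of a number 0.14 log units higher from compound 2 to compound 1 (within the scatter) lies within the scatter. Compound 3 carries a different core from compound 2; the difference between the two cores is not broken down here, and only the two values themselves can be compared.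

Compound 4 `CCN(C)/N=N/c1ccc(C(N)=O)cc1` has not yet been measured. It differs from compound 3 by amino in place of ethoxy on a carbonyl carbon, the same change as from compound 2 to compound 1, made at a place described in the same words. Because the earlier step of a number 0.14 log units higher from compound 2 to compound 1 (within the scatter) was within the scatter, the step is expected to be small, a number 0.14 log units higher from compound 3 to compound 4 (within the scatter), in this assay. On that basis compound 4 is estimated at 3.15, with a likely range from 2.75 to 3.55.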

Compound 4, logarithm of the reciprocal of the active concentration, log(1/C): 3.66
Compound 4: middle estimate off by 0.51 log units, on the low side, and the stated range ends below it.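

In this assay, amino in place of ethoxy on a carbonyl carbon gives a number 0.65 log units higher from compound 3 to compound 4 (beyond the scatter), and this step does not match the one seen on the other core: the same change on two cores in this assay, a number 0.14 log units higher (within the scatter) from compound 2 to compound 1 and a number 0.65 log units higher (beyond the scatter) from compound 3 to compound 4, 0.51 log units apart, beyond the scatter of two such steps The size of this change therefore cannot be carried unaltered from the core of compound 1 to the core of compound 4. With only these two pairs, the data do not show which feature of the two cores accounts for the gap, nor what size the step would take on any further core.

The compounds shown leave open whether a carboxylic acid or a methylamide in place of the ethoxy group would also give steps that differ between the two cores. They also leave open whether the larger step would hold with a longer chain in place of the ethyl group of compound 4.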